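Extending the Aryl Arm of a Quinuclidinyl Carbamate

The compounds below may be only part of what the source reports. "The series", "measured", "known", "first", "only" and "open" are said of these compounds alone.

Compound 3 `O=C(OCCc1ccccc1)N(c1ccccc1)C1CN2CCC1CC2` gives 260 nM in an assay on CHO cells for displacement of a labelled ligand from muscarinic acetylcholine receptor M5 (Homo sapiens), read by scintillation counting, with a stated time of 2 h (a lower number here means a stronger inhibitor, a higher number a weaker inhibitor), the highest of the three numbers measured. Compound 2 `COc1ccc(CCOC(=O)N(c2ccccc2)C2CN3CCC2CC3)cc1` gives 230 nM, and the step of a 1.1-fold higher number from compound 2 to compound 3 (0.05 log units; within the scatter) falls within the scatter, so the methoxy group alone leaves the number essentially unchanged. Compound 1 `O=C(OCCc1ccc(Cl)c(Cl)c1)N(c1ccccc1)C1CN2CCC1CC2` gives 80 nM, and the step of a 3.3-fold higher number from compound 1 to compound 3 (0.51 log units; beyond the scatter) is modest but real. The untested compound 4 `COc1ccc(CCCOC(=O)N(c2ccccc2)C2CN3CCC2CC3)cc1F` differs from compound 3 by 3-fluoro-4-methoxybenzyl in place of phenyl on a saturated chain carbon, two bonds along the chain from an oxygen next to a carbonyl group. Among the compounds with values here, the methoxy part of this change is covered by the step from compound 2; the fluorine and the benzyl linkage have no measured precedent, though compound 1 shows that a halogenated ring can lower the number. He therefore expects compound 4 to give 200 nM, within 70 nM to 600 nM, a step of a 1.3-fold lower number from compound 3 to compound 4 (0.11 log units; within the scatter) that stays close to the scatter.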

Compound 4, inhibition constant: 260 nM
For compound 4 the middle estimate is 1.3-fold (0.11 log units) below the measured one, within the range that was stated.
By their numbers in this assay, from the lowest: compound 1; then compounds 2, 3 and 4 (each within the scatter of the next).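

In this assay, 3-fluoro-4-methoxybenzyl in place of phenyl gives no change at the digits printed from compound 3 to compound 4 (within the scatter), and in place of 4-methoxyphenyl it gives a 1.1-fold higher number from compound 2 to compound 4 (0.05 log units; within the scatter), so this place accepts a larger group with a benzyl linkage without any step beyond the scatter. Against 3,4-dichlorophenyl it gives a 3.3-fold higher number from compound 1 to compound 4 (0.51 log units; beyond the scatter), which leaves compound 1 as the only compound set apart from the others. Nothing available explains this result. The compounds shown leave open what the fluorine and the benzyl linkage each do alone, as they enter together. They also leave open whether 3,4-dichlorobenzyl or a longer chain here would keep the lower number of compound 1.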